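The source may hold more compounds than are shown below. What is called first, only, known or untested is meant among the compounds shown, and "the series" means these compounds.

Measured compounds in a functional assay on NCI-H460 cells (Homo sapiens) for inhibition, read by MTT assay, with a stated time of 72 h; on this read-out lower numbers stand for stronger inhibition and higher numbers for weaker inhibition:
- compound 1, `O=c1[nH]c(=O)n(COC(CO)CO)cc1O`: compound 1 gives > 100000 nM, a limit of the assay rather than a number.
- compound 2, `O=C(CCl)Nc1cn(COC(CO)CO)c(=O)[nH]c1=O`: compound 2 gives 24000 nM.
- compound 3, `Cc1ccc(S(=O)(=O)Nc2ccn(C)c(=O)n2)cc1`: compound 3 gives > 100000 nM, again a limit and not a number.

Among the compounds with values here, compound 2 therefore stands as the only member of this small set for which this assay returns a number at all; the other two values sit at the limit of > 100000 nM in this assay, at which 2 of the 3 values shown sit. Within the data shown here, the one measured step that reaches compound 2 is an at least 4.1-fold lower number from compound 1 to compound 2 (0.61 log units; beyond the scatter), so the ((chloromethyl)carbonyl)amino group is the only change in this set that moves the read-out away from the limit.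

The next compound, compound 4, `Nc1cn(COC(CO)CO)c(=O)[nH]c1=O`, has not yet been measured. It differs from compound 2 by hydrogen in place of (chloromethyl)carbonyl on a nitrogen on an aromatic ring. Among the measured compounds shown here, no measured step covers this exact change, but the step of an at least 4.1-fold lower number from compound 1 to compound 2 (0.61 log units; beyond the scatter) shows what the ((chloromethyl)carbonyl)amino group brought relative to hydroxy, and removing the (chloromethyl)carbonyl part takes most of that group away again. The account therefore expects the number to rise, with compound 4 likely moving back toward the limit, the expected step being a 3.3-fold higher number from compound 2 to compound 4 (0.52 log units; beyond the scatter). Compound 4 is estimated at 80000 nM, within a range from 20000 nM to 300000 nM.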

Compound 4, half-maximal inhibitory concentration: > 100000 nM
Compound 4 gave a limit, no number; the forecaster's own chance of this, stated with the estimate: 55%; middle value at least 1.2-fold (0.09 log units) from the limit.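

In this assay, the step to the free amino form, an at least 4.1-fold higher number from compound 2 to compound 4 (0.61 log units; beyond the scatter), shows that a nitrogen on this aromatic carbon does not by itself bring the read-out away from the limit; the measurable number goes with the (chloromethyl)carbonyl carried on that nitrogen. The earlier step set the whole ((chloromethyl)carbonyl)amino group against hydroxy, so it could not separate the nitrogen from the (chloromethyl)carbonyl part, and this new pair does. The step between compound 1 and compound 4 cannot be read, as both ends are limits, and the set now stands as follows: the limit of > 100000 nM in this assay, at which 3 of the 4 values shown sit.

The compounds shown leave open which part of the (chloromethyl)carbonyl group goes with the number, since an acetyl group, with hydrogen in place of the chlorine, or a bromoacetyl group on the same nitrogen would set the chlorine apart from the carbonyl. They also leave open whether a longer acyl chain, such as chloropropanoyl, would keep, lower or raise the number seen for compound 2.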